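The compounds below may be only part of what the source reports. "The series", "measured", "known", "first", "only" and "open" are said of these compounds alone.

Working notes on the varied group on the shared core. Compound 1 `COc1cccc(CNCCCNc2ccnc3cc(Oc4ccc(F)cc4)ccc23)c1O` in a physicochemical assay for solubility, with a stated time of 18 h, at pH 7.4 (on this read-out lower numbers stand for lower solubility and higher numbers for higher solubility), gives 14500 nM. Compound 2 `COc1cccc(CNCCCNc2ccnc3cc(-c4cccc5ccccc45)ccc23)c1O` in this assay gives 32000 nM, and compound 3 `COc1cccc(CNCCCNc2ccnc3cc(CC4CCCCC4)ccc23)c1O` gives 4200 nM. Compound 3 holds the lowest of the three numbers: the steps of a 3.5-fold lower number from compound 1 to compound 3 (0.54 log units; beyond the scatter) and a 7.6-fold lower number from compound 2 to compound 3 (0.88 log units; beyond the scatter) both run downward to it and both lie beyond the scatter, while a 2.2-fold higher number from compound 1 to compound 2 (0.34 log units; beyond the scatter) sets compound 2 at the top.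

Compound 4 `COc1cccc(CNCCCNc2ccnc3cc(Cc4cccc(C(F)(F)F)c4)ccc23)c1O` is not yet measured. Its change from compound 3 is 3-(trifluoromethyl)phenyl in place of cyclohexyl on a saturated chain carbon bound to an aromatic carbon. The step that bears most on this is a 7.6-fold lower number from compound 2 to compound 3 (0.88 log units; beyond the scatter), where an aromatic group gave way to cyclohexylmethyl and the number fell; a 3.5-fold lower number from compound 1 to compound 3 (0.54 log units; beyond the scatter) points the same way. Returning from cyclohexyl to an aromatic ring, here 3-(trifluoromethyl)phenyl, is therefore expected to raise the number in this assay by a modest step, a 1.9-fold higher number from compound 3 to compound 4 (0.28 log units; within the scatter), though the trifluoromethyl group has no precedent in the set. Compound 4 is estimated at 8000 nM, within 3500 nM to 18000 nM.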

Compound 4, solubility: 4200 nM
Compound 4: middle estimate off by 1.9-fold (0.28 log units), on the high side; the measured number falls inside the stated range.
By their numbers in this assay, from the lowest: compounds 3 and 4 (each within the scatter of the next); then compound 1; then compound 2.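

On the saturated chain carbon bound to an aromatic carbon, 3-(trifluoromethyl)phenyl in place of cyclohexyl gives no change at the digits printed from compound 3 to compound 4 (within the scatter) in this assay, so an aromatic ring at this place does not by itself lift the number towards those of compounds 1 and 2. The other two steps, a 7.6-fold lower number from compound 2 to compound 4 (0.88 log units; beyond the scatter) and a 3.5-fold lower number from compound 1 to compound 4 (0.54 log units; beyond the scatter), match the size of those to compound 3, and among these four compounds the two lower numbers go with a ring held on a saturated chain carbon, whether aromatic or not. No measurement shown accounts for this result.

Open, as far as these compounds go, is how a ring bearing an amine or a carboxylic acid would read on this saturated chain carbon, or a longer chain in its place. Among the compounds shown, unsubstituted phenyl is absent, so the share of the trifluoromethyl group in the number of compound 4 stays unread.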